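The source may report more compounds than this note shows. Statements on the series, on what has been measured and on what is new or still open speak of the compounds shown alone.

Working notes on the series. Three compounds share the core of compound 1 `CC/C=C\COC1(c2ccc(Cl)cc2)SC=C(C)n2c1noc2=O` and have numbers in a functional assay on A2780/DX3 cells (Homo sapiens) for antiproliferative activity, read by MTT assay, with a stated time of 3 days; on this read-out lower numbers stand for stronger inhibition and higher numbers for weaker inhibition. In this assay compound 1 gives 103000 nM. Compound 3 `CC1=CSC(O)(c2cccc(C(F)(F)F)c2)c2noc(=O)n21` gives 71000 nM in this assay. Compound 2 `O=c1onc2n1C=CSC2(O)c1ccc(Cl)cc1` is recorded in this assay only as a limit, > 100000 nM, and not as a number. The relevant point for what follows is the limit of > 100000 nM in this assay, at which 1 of the 3 values shown sits, so compound 2 stands at the weak edge of what the read-out can report, and the other two numbers sit not far from it. Going by the values given here, no pair of measured compounds differs in one place, so no measured step is available to compare against.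

Compound 4 `O=c1onc2n1C=CSC2(O)c1ccccc1` is the next compound to be measured in this assay. It differs from compound 2 by hydrogen in place of chloro on an aromatic carbon. With the whole series near the upper end of the read-out and compound 2 itself at a limit, no step beyond the usual scatter is expected in either direction. The step of a number no higher from compound 2 to compound 4 (the limit leaves the size open) is the expected one, that is, essentially none. For compound 4 the estimate in this assay is 100000 nM, within a range from 50000 nM to 300000 nM, with a fair chance that only a limit is reported again.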

Compound 4, half-maximal inhibitory concentration: > 100000 nM
Compound 4 ended at the assay's limit; the forecaster's own chance of this, stated with the estimate: 55%; the middle value sits exactly at the limit.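

Compound 2 and compound 4 are both recorded in this assay only as limits, so no step can be read for hydrogen in place of chloro on an aromatic carbon: the limit of > 100000 nM in this assay, at which 2 of the 4 values shown sit.

The compounds shown leave open whether hydrogen in place of chloro changes anything in this assay, and how far past the limit compound 2 and compound 4 lie.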